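The source may hold more compounds than are shown below. What is called first, only, known or untested is meant among the compounds shown, and "the series" means these compounds.

Compound 1 `Cc1ccc(S(=O)(=O)N[C@@H](CC(=O)NC(C)(C)C)C(=O)NCCNC(=O)c2cc(Cl)ccn2)cc1` and compound 2 `Cc1ccc(S(=O)(=O)N[C@@H](CC(=O)NC(C)(C)C)C(=O)NCCNC(=O)c2ccccc2Cl)cc1` share one core and differ only in the group on the carbonyl carbon. In an ADME assay on HepG2 cells (Homo sapiens) for cytotoxicity (on this read-out higher numbers stand for an effect only at larger amounts of compound and lower numbers for an effect already at smaller amounts), compound 1 gives a limit of the assay, > 11000 nM. In this assay compound 2 likewise gives only a limit, > 11000 nM. Within the data shown here, the one measured step, a step that the two limits leave unreadable from compound 1 to compound 2, therefore cannot be read as a number, since both values sit at the limit of > 11000 nM in this assay, at which 2 of the 2 values shown sit. Compound 2 thus stands at the limit of this assay together with compound 1, with no graded number to place it.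

Compound 3 `Cc1ccc(S(=O)(=O)N[C@@H](CC(=O)NC(C)(C)C)C(=O)NCCNC(=O)c2ccc(F)c(F)c2)cc1` is the next member and differs from compound 2 by 3,4-difluorophenyl in place of 2-chlorophenyl on a carbonyl carbon. Among the measured compounds shown here, no measured step bears directly on a change of this kind; the only step available is unreadable. With both known values at the limit, the expectation is no step beyond the scatter, and the step from compound 2 to compound 3 is expected as a step that the limit leaves unreadable from compound 2 to compound 3. Compound 3 is estimated at 15000 nM, within 8000 nM to 40000 nM, and most likely is again reported only as a limit.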

Compound 3, half-maximal effective concentration: > 11000 nM
Compound 3 was reported as a limit (the forecaster's own chance of this, stated with the estimate: 85%); the middle value lies beyond the limit too.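

Among these compounds, compound 3 joins compound 1 and compound 2 as a limit in this assay and no step among the three can be read: the limit of > 11000 nM in this assay, at which 3 of the 3 values shown sit. The compounds shown leave open how far any of the three lies beyond that limit, and whether any group on the carbonyl carbon would give a graded value.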